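The source may report more compounds than this note shows. Statements on the series, on what has been measured and on what is new or still open speak of the compounds shown alone.

Going by the values given here, compound 2 `O=C(CCC(=O)OCCCCCCSc1ccc([N+](=O)[O-])c2nonc12)Nc1ccc(F)cc1` and compound 1 `Cc1ccccc1NC(=O)CCC(=O)OCCCCCCSc1ccc([N+](=O)[O-])c2nonc12` are the two compounds measured so far. In a functional assay on A549 cells (Homo sapiens) for inhibition, read by MTT assay, with a stated time of 72 h (a lower number here means a stronger inhibitor, a higher number a weaker inhibitor), compound 2 gives 6300 nM, and compound 1 gives 4200 nM; the two values lie within the scatter of each other. Among the compounds with values here, the one measured step, a 1.5-fold higher number from compound 1 to compound 2 (0.18 log units; within the scatter), exchanged one substituted phenyl for another on the amide nitrogen and stayed within the scatter. Compound 3 `COc1ccc(NC(=O)CCC(=O)OCCCCCCSc2ccc([N+](=O)[O-])c3nonc23)cc1` differs from compound 2 by methoxy in place of fluoro on an aromatic carbon. Within the data shown here, only that small step bears on this change, so compound 3 is expected to move by a 1.1-fold lower number from compound 2 to compound 3 (0.02 log units; within the scatter), within the scatter. Compound 3 is estimated at 6000 nM, between 2500 nM and 14000 nM.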

Compound 3, half-maximal inhibitory concentration: 6480 nM
Compound 3: middle estimate off by 1.1-fold (0.03 log units), on the low side; the measured number falls inside the stated range.
By their numbers in this assay, from the lowest: compounds 1, 2 and 3 (each within the scatter of the next).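

In this assay, methoxy in place of fluoro on the aromatic carbon para to a large group gives a 1.0-fold higher number from compound 2 to compound 3 (0.01 log units; within the scatter), so adding a hydrogen-bond acceptor here leaves the number within the scatter. The 4-methoxyphenyl in place of 2-methylphenyl on the amide-type nitrogen gives a 1.5-fold higher number from compound 1 to compound 3 (0.19 log units; within the scatter), so all three aryl groups shown read alike. Nothing available explains this sameness. Still open, on these data alone, is whether an amine or a carboxylic acid at this position would move the number beyond the scatter. A longer chain on the shared core is also untested among these compounds.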